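From tert-butyl to benzimidazolylmethyl on an aromatic nitrogen

The compounds below may be only part of what the source reports. "The series", "measured", "known", "first", "only" and "open" are said of these compounds alone.

Of the compounds shown here, three sharing one core have been tested in a functional assay on HCC827 cells (Homo sapiens) for antiproliferative activity, read by sulforhodamine B assay, with a stated time of 72 h; on this read-out higher numbers stand for weaker inhibition and lower numbers for stronger inhibition. Compound 1 `CN(CCNCc1cn(-c2ccc(Cl)cc2)nn1)CCNc1ccnc2cc(Cl)ccc12` gives 9500 nM. Compound 2 `CN(CCNCc1cn(Cc2ccc(Br)cc2)nn1)CCNc1ccnc2cc(Cl)ccc12` gives 9300 nM. Compound 3 `CN(CCNCc1cn(C(C)(C)C)nn1)CCNc1ccnc2cc(Cl)ccc12` gives 56000 nM, the highest of the three numbers, separated from both others by steps beyond the scatter: a 5.9-fold higher number from compound 1 to compound 3 (0.77 log units; beyond the scatter) and a 6.0-fold higher number from compound 2 to compound 3 (0.78 log units; beyond the scatter). Compound 4 `CN(CCNCc1cn(Cc2nc3ccccc3[nH]2)nn1)CCNc1ccnc2cc(Cl)ccc12` carries (1H-benzimidazol-2-yl)methyl in place of tert-butyl on an aromatic nitrogen. The two measured steps bear on this change in reverse, since each swapped an aryl-bearing group for tert-butyl with a modest rise; putting an aryl-bearing group back is therefore expected to lower the number by a comparable amount, a 5.9-fold lower number from compound 3 to compound 4 (0.77 log units; beyond the scatter). Compound 4 is estimated at 9500 nM, with a range from 3000 nM to 30000 nM.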

Compound 4, half-maximal inhibitory concentration: 164000 nM
Compound 4: the middle estimate sits 17-fold (1.24 log units) below what was measured; the measured number lies above the stated range.
By their numbers in this assay, from the lowest: compounds 2 and 1 (each within the scatter of the next); then compound 3; then compound 4.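

In this assay, a ring-bearing group on this aromatic nitrogen does not by itself lower the number: (1H-benzimidazol-2-yl)methyl in place of tert-butyl gives a 2.9-fold higher number from compound 3 to compound 4 (0.47 log units; beyond the scatter). Measured against the other two groups, the same substituent gives an 18-fold higher number from compound 2 to compound 4 (1.25 log units; beyond the scatter) and a 17-fold higher number from compound 1 to compound 4 (1.24 log units; beyond the scatter), so this position separates ring-bearing groups from one another, not only from tert-butyl. No measurement at hand explains this reversal. As far as these compounds go, it remains open whether a plain benzyl or a pyridin-2-ylmethyl group would fall nearer compound 2 or compound 4.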